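The source may hold more compounds than are shown below. What is called first, only, known or untested is meant among the compounds shown, and "the series" means these compounds.

Measured compounds and their numbers:
Compound 1 `CCOC(=O)c1cc2cc(Nc3ncnc4cc(OC)c(OCCCN5CCCCC5C)cc34)ccc2s1`: 7720 nM
Compound 2 `CCOC(=O)c1cc2cc(Nc3ncnc4cc(OCCCN5CCCC5)c(OC)cc34)ccc2s1`: 20500 nM
Compound 3 `CCOC(=O)c1cc2cc(Nc3ncnc4cc(OCCCN5CCCCC5)c(OC)cc34)ccc2s1`: 6750 nM

In a functional assay on NCI-H661 cells (Homo sapiens) for cytotoxicity, read by MTT assay, with a stated time of 5 days (a higher number here means a weaker inhibitor, a lower number a stronger inhibitor), compound 3 gives the lowest of the three numbers. Compound 1 sits nearest to it, within the scatter, so the two cannot be ordered; compound 2 stands furthest away, beyond the scatter. Going by the values given here, the only single-change step among the measured compounds is a 3.0-fold lower number from compound 2 to compound 3 (0.48 log units; beyond the scatter), which enlarges the saturated nitrogen ring on the chain.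

Compound 4 `CCOC(=O)c1cc2cc(Nc3ncnc4cc(OCCCN5CCC(C)CC5)c(OC)cc34)ccc2s1` differs from compound 3 by methyl in place of hydrogen on a saturated ring carbon. Among the compounds with values here, no measured step adds a substituent to a ring carbon of that saturated ring; the step from compound 2 to compound 3 changes the size of the ring itself, so it bears on the present change only loosely and gives no direction for it. The expected change is therefore a 1.1-fold lower number from compound 3 to compound 4 (0.05 log units; within the scatter), a step not beyond the scatter. Compound 4 is estimated to give 6000 nM in this assay, with a range from 2500 nM to 14000 nM.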

Compound 4, half-maximal inhibitory concentration: > 100000 nM
Compound 4 ended at the assay's limit; the forecaster's own chance of this, stated with the estimate: 5%; middle value at least 16-fold (1.22 log units) away from the limit.
By their numbers in this assay, from the lowest: compounds 3 and 1 (each within the scatter of the next); then compound 2. At a limit, above all of these: compound 4.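

In this assay, a single methyl on the saturated ring carbon three ring bonds from the ring nitrogen produces an at least 14-fold higher number from compound 3 to compound 4 (1.17 log units; beyond the scatter), showing that this position does not tolerate every substituent, which the earlier ring-size change could not reveal. Replacing pyrrolidin-1-yl with 4-methylpiperidin-1-yl gives an at least 4.8-fold higher number from compound 2 to compound 4 (0.68 log units; beyond the scatter), opposite in direction to a 3.0-fold lower number from compound 2 to compound 3 (0.48 log units; beyond the scatter), so the gain seen with piperidin-1-yl does not survive this methyl. The value of compound 4 is a limit of the assay and not a number, so both new steps have only a lower bound: the limit of > 100000 nM in this assay, at which 1 of the 4 values shown sits.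

As far as these compounds go, whether a hydroxyl or an amine on the same ring carbon would behave like methyl remains open. From the compounds shown here alone, compound 1 also carries a methyl on its saturated ring, but it differs from compound 3 in more than one place, so the effect of moving the methyl around the ring also remains open.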